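A Methyl on the Pyridine Ring of Compound 2

The source may hold more compounds than are shown below. What is called first, only, known or untested is meant among the compounds shown, and "the series" means these compounds.

Compound 1, `CCc1ccccc1N(CC(=O)NCc1ccccc1)S(=O)(=O)c1ccc(C)cc1`, gives 224 nM in a functional assay on CHO-K1 cells for antagonist activity at prostaglandin E2 receptor EP1 subtype (Homo sapiens), read by FLIPR and calcium flux; a higher number here means a weaker inhibitor, a lower number a stronger inhibitor.
Compound 2, `Cc1ccc(S(=O)(=O)N(CC(=O)NCc2ccc(Cl)cc2)c2ccccn2)cc1`, gives < 1450 nM in this assay.

For compound 2 this value is a limit of the assay and not a number (the limit of < 1450 nM in this assay, at which 1 of the 2 values shown sits). Compound 3, `Cc1ccc(S(=O)(=O)N(CC(=O)NCc2ccc(Cl)cc2)c2cccc(C)n2)cc1`, differs from compound 2 by methyl in place of hydrogen on an aromatic carbon. No step between measured compounds is shown, so the effect of this change is unknown; in this assay a step from compound 2 to compound 3 no larger than the usual scatter is expected, in either direction. Compound 3 is therefore estimated at 600 nM, between 150 nM and 2500 nM. The expected step is a step that the limit leaves unreadable from compound 2 to compound 3.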

Compound 3, inhibition constant: < 1450 nM
Compound 3: no number, only a limit (the forecaster's own chance of this, stated with the estimate: 25%); the middle value does not contradict the limit.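

Compound 2 and compound 3 each give only a limit of the assay, so no step can be read between them: the limit of < 1450 nM in this assay, at which 2 of the 3 values shown sit.

The compounds shown leave open whether going from pyridin-2-yl to 6-methylpyridin-2-yl changes the inhibition constant in this assay at all, and in which direction.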